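A few compounds are considered here, and "the series" means these few. Any claim that something is new, unique, unknown or untested is made for them only; others in the source may bear on it.

Working notes on the series.

Compound 1 `CNC(=O)[C@@]12C[C@@H]1[C@@H](n1cnc3cnc(/C=C(\O)c4cnccn4)nc31)[C@H](O)[C@@H]2O` is the weaker of the two measured entries. In an assay on CHO cells for displacement of a labelled ligand from transmembrane domain-containing protein TMIGD3 (Homo sapiens), read by scintillation counting, with a stated time of 60 min (a higher number here means a weaker inhibitor, a lower number a stronger inhibitor), compound 1 gives 1480 nM, the highest number recorded so far. For the measured compounds named here, the only other measured compound, compound 2 `CNC(=O)[C@@]12C[C@@H]1[C@@H](n1cnc3c(C)nc(C#Cc4ccccc4)nc31)[C@H](O)[C@@H]2O`, stands far below it: in this assay compound 2 gives 6.01 nM, a gap that lies well beyond the usual scatter. Going by the values given here, the two differ at more than one place, so no single step between them is defined; the pair shows only that the shared core can carry much stronger inhibition than compound 1 does.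

Compound 3 `CNC(=O)[C@@]12C[C@@H]1[C@@H](n1cnc3cnc(NC)nc31)[C@H](O)[C@@H]2O` has not yet been measured. Relative to compound 1 the change is methylamino in place of 2-hydroxy-2-(pyrazin-2-yl)ethenyl on an aromatic carbon. The large 2-hydroxy-2-(pyrazin-2-yl)ethenyl group is exchanged for a small methylamino group on the same aromatic carbon of the core. Among the compounds with values here, no measured pair isolates this exchange, so the expectation rests on compound 1 alone and on the much lower number of compound 2.

For compound 3 a moderate fall in the number is expected, a 4.9-fold lower number from compound 1 to compound 3 (0.69 log units; beyond the scatter), beyond the scatter but far from the level of compound 2. The estimate for compound 3 in this assay is 300 nM, with a range from 40 nM to 2500 nM.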

Compound 3, inhibition constant: 604 nM
Beside the measured number, compound 3's estimate is 2.0-fold (0.30 log units) below it, and the stated range covers the measured number.
By their numbers in this assay, from the lowest: compound 2; then compound 3; then compound 1.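

This aromatic carbon, between two ring nitrogen atoms, does not depend on the large group of compound 1 for inhibition: exchanging 2-hydroxy-2-(pyrazin-2-yl)ethenyl for methylamino gives a 2.5-fold lower number from compound 1 to compound 3 (0.39 log units; beyond the scatter) in this assay and is a modest step in the stronger direction. The six-membered aromatic ring and the double bond outside it can therefore leave this position together without any loss, and a small group with no ring is enough to keep the number in this range. Nothing at hand explains why the number falls with this exchange.

The compounds shown leave open whether the lower number comes from removing the large group or from the methylamino group itself, as this single step changes both at once. A bare hydrogen, an unsubstituted amine, a dimethylamino group or a longer alkylamine chain on the same aromatic carbon would separate those two readings and show how much size the position accepts before the number rises again.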